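Where a second methoxy group might take the number

The source may hold more compounds than are shown below. What is called first, only, known or untested is meant among the compounds shown, and "the series" means these compounds.

Compound 1 `O=C(Nc1cccc(-c2oc3cc(-c4ccc(F)cc4)ccc3c(=O)c2O)c1)c1ccccc1F` is the anchor of this small set. In a functional assay on A549 cells (Homo sapiens) for antiproliferative activity, read by CCK-8 assay, with a stated time of 72 h (on this read-out higher numbers stand for weaker inhibition and lower numbers for stronger inhibition), compound 1 gives 4410 nM, the lowest of the three numbers obtained so far. Compound 2 `O=C(Nc1cccc(-c2oc3cc(-c4ccc(F)cc4)ccc3c(=O)c2O)c1)c1ccc(F)cc1F` gives 20500 nM in this assay, and compound 3 `COc1cccc(C(=O)Nc2cccc(-c3oc4cc(-c5ccc(F)cc5)ccc4c(=O)c3O)c2)c1` gives 10800 nM. Both steps away from compound 1 lead to higher numbers: a 4.6-fold higher number from compound 1 to compound 2 (0.67 log units; beyond the scatter) and a 2.4-fold higher number from compound 1 to compound 3 (0.39 log units; beyond the scatter). Compound 2 and compound 3 lie within the scatter of each other, as a 1.9-fold lower number from compound 2 to compound 3 (0.28 log units; within the scatter) shows.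

Compound 4 `COc1cc(OC)cc(C(=O)Nc2cccc(-c3oc4cc(-c5ccc(F)cc5)ccc4c(=O)c3O)c2)c1` awaits measurement. Against compound 1 the change is 3,5-dimethoxyphenyl in place of 2-fluorophenyl on a carbonyl carbon. Going by the values given here, the step that bears on it most directly is the one from compound 1 to compound 3, in which a methoxy-bearing phenyl also replaced the 2-fluorophenyl on the carbonyl carbon; that step was modest yet beyond the scatter. The step from compound 1 to compound 2 concerns a different change and offers no direct guide. Among the compounds with values here, no measured compound carries two methoxy groups, so the uncertainty is wider than for compound 3. A modest rise is expected in this assay, giving compound 4 an estimated 12000 nM, within a range from 5000 nM to 30000 nM. The expected step is a 2.7-fold higher number from compound 1 to compound 4 (0.43 log units; beyond the scatter).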

Compound 4, half-maximal inhibitory concentration: 2390 nM
Beside the measured number, compound 4's estimate is 5.0-fold (0.70 log units) above it; the measured number lies below the stated range.
By their numbers in this assay, from the lowest: compounds 4 and 1 (each within the scatter of the next); then compounds 3 and 2 (each within the scatter of the next).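

On the carbonyl carbon whose other neighbour is the amide-type nitrogen, the second methoxy group changes the outcome: this assay gives a 4.5-fold lower number from compound 3 to compound 4 (0.66 log units; beyond the scatter), so the higher number seen with a single methoxy group does not carry over to the 3,5-dimethoxyphenyl group. The exchange of 2-fluorophenyl for 3,5-dimethoxyphenyl gives a 1.8-fold lower number from compound 1 to compound 4 (0.27 log units; within the scatter) and stays within the scatter, so the two groups cannot be told apart here, and a fluorine on this ring is not needed for a number in this low range. The set also shows that the number does not simply follow the count of substituents on this ring, since the step with two groups on each side gives an 8.6-fold lower number from compound 2 to compound 4 (0.93 log units; beyond the scatter) for 3,5-dimethoxyphenyl in place of 2,4-difluorophenyl.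

Nothing shown gives a reason for these differences. As far as these compounds go, whether the two methoxy groups must stand in this arrangement remains open, as does what an amine, a carboxylic acid or a longer alkoxy chain on this ring would do to the number.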